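Swapping the Pendant Aryl Group: Expected Microsomal Clearance

The compounds below may be only part of what the source reports. "The series", "measured", "known", "first", "only" and "open" are said of these compounds alone.

Measured so far:
compound 1, `COc1cc(C(O)(C(F)(F)F)C(F)(F)F)cnc1N1CCN(S(=O)(=O)c2ccc(N)nc2)CC1`: < 14 mL.min-1.g-1
compound 2, `CS(=O)(=O)Nc1cccc(-c2cc(C(O)(C(F)(F)F)C(F)(F)F)cnc2N2CCN(S(=O)(=O)c3ccc(N)nc3)CC2)c1`: 40 mL.min-1.g-1

In an ADME assay (liver) for metabolic stability, with Liver microsome (Homo sapiens) as the target, using microsomes and NADPH, with a stated time of 30 min, tested at 1 uM (a higher number here means faster removal of the compound, a lower number slower removal), compound 1 gives only a limit, < 14 mL.min-1.g-1. Within the data shown here, compound 2 gives 40 mL.min-1.g-1, the only actual number in this assay so far. The step of an at least 2.8-fold higher number from compound 1 to compound 2 (0.45 log units; beyond the scatter) is therefore known only as a lower bound, because compound 1 sits at the limit of < 14 mL.min-1.g-1 in this assay, at which 1 of the 2 values shown sits.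

Compound 3, `Nc1ccc(S(=O)(=O)N2CCN(c3ncc(C(O)(C(F)(F)F)C(F)(F)F)cc3-c3ccc4c(c3)CC(=O)N4)CC2)cn1`, is not yet measured. The change from compound 2 is a group of 10 heavy atoms (8 carbon, 1 nitrogen, 1 oxygen; one five-membered non-aromatic ring with 1 hetero atom, one six-membered aromatic ring of carbon only) in place of a group of 11 heavy atoms (7 carbon, 1 nitrogen, 2 oxygen, 1 sulfur; one six-membered aromatic ring of carbon only), on an aromatic carbon.

Among the measured compounds shown here, the single measured step concerns a different change, the addition of a large group to the shared core, and no measured pair shows a swap of one such group for another. With nothing to point in either direction, the expectation is a step of no change at the digits printed from compound 2 to compound 3 (within the scatter), within the scatter. Compound 3 is estimated at 40 mL.min-1.g-1, most likely between 18 mL.min-1.g-1 and 90 mL.min-1.g-1.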

Compound 3, intrinsic clearance in microsomes: < 14 mL.min-1.g-1
Compound 3 ended at the assay's limit (the forecaster's own chance of this, stated with the estimate: 15%); middle value at least 2.8-fold (0.45 log units) from the limit.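

In this assay, putting the group with the five-membered non-aromatic ring in place of the 3-(methanesulfonamido)phenyl group gives an at least 2.8-fold lower number from compound 2 to compound 3 (0.45 log units; beyond the scatter). At this position, on an aromatic carbon ortho to a large group, the number therefore depends on which large group is present, and carrying one does not by itself keep the number high. Compound 3 gives < 14 mL.min-1.g-1, which is a limit of the assay and not a number, and the step is only a lower bound because of where compound 3 sits: the limit of < 14 mL.min-1.g-1 in this assay, at which 2 of the 3 values shown sit.

The step between compound 1 and compound 3 cannot be read, as both ends are limits. Also open, going by these compounds, is which part of the 3-(methanesulfonamido)phenyl group goes with the higher number, a question that a plain phenyl or a phenyl carrying an amine in the same place would address.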